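A few compounds are considered here, and "the series" means these few. Any claim that something is new, unique, unknown or untested is made for them only; others in the source may bear on it.

Compound 3 `COc1cc(C(=O)NO)ccc1CN(C(C)C)S(=O)(=O)c1cc(F)c(F)c(F)c1F` carries a methoxy group on its aromatic core, with a sulfonamide nitrogen that bears an isopropyl group. In an assay on Sf9 cells for inhibition of protein deacetylase HDAC6 (Homo sapiens), read by fluorescence and mobility shift assay (a lower number here means a stronger inhibitor, a higher number a weaker inhibitor), compound 3 gives only a limit, > 1000 nM, which means the assay could not put a number on it. Compound 4 `CC(C)N(Cc1ccc(C(=O)NO)cc1)S(=O)(=O)c1cc(F)c(F)c(F)c1F` differs from compound 3 in one place: hydrogen in place of methoxy on an aromatic carbon of a six-membered aromatic ring of carbon only, ortho to a large group and meta to the hydroxycarbamoyl group. Within the data shown here, no measured step touches this aromatic position. Among the measured compounds shown here, the one measured step, a 2.9-fold higher number from compound 1 to compound 2 (0.46 log units; beyond the scatter), changes the group on the sulfonamide nitrogen instead, and compound 1 `O=C(NO)c1ccc(CN(C2CC2)S(=O)(=O)c2cc(F)c(F)c(F)c2F)cc1` gives 8.5 nM in this assay, while compound 2 `CC(C)CN(Cc1ccc(C(=O)NO)cc1)S(=O)(=O)c1cc(F)c(F)c(F)c1F` gives 24.6 nM. Compound 4 shares the unsubstituted core of these two compounds, so it is expected to sit close to them, with an estimated at least 66-fold lower number from compound 3 to compound 4 (1.82 log units; beyond the scatter) that leaves the limit far behind. The estimate for compound 4 is 15 nM, expected to fall between 5 nM and 60 nM.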

Compound 4, half-maximal inhibitory concentration: 6 nM
For compound 4 the middle estimate is 2.5-fold (0.40 log units) above the measured one; measured number inside the range.
By their numbers in this assay, from the lowest: compounds 4 and 1 (each within the scatter of the next); then compound 2. At a limit, above all of these: compound 3.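

In this assay, this aromatic position matters more than any change yet seen on the sulfonamide nitrogen: hydrogen in place of methoxy gives an at least 160-fold lower number from compound 3 to compound 4 (2.22 log units; beyond the scatter). Compound 3 gives only a limit, not a number, so the true size of that step stays unknown: the limit of > 1000 nM in this assay, at which 1 of the 4 values shown sits.

On the nitrogen, isopropyl in place of isobutyl gives a 4.1-fold lower number from compound 2 to compound 4 (0.61 log units; beyond the scatter), while isopropyl in place of cyclopropyl gives a 1.4-fold lower number from compound 1 to compound 4 (0.15 log units; within the scatter), so isopropyl and cyclopropyl cannot be told apart here.

The compounds shown carry only methoxy or hydrogen at this aromatic position, so it remains open whether a fluorine atom or a methyl group there would give a number close to that of compound 4. On these data alone, how a longer chain or an amine on the sulfonamide nitrogen would compare also remains open.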